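Pyridin-4-yl Replaces Chlorothiophene on a Phenoxyacetic Acid Alkyne

This account rests on a few compounds, and the source may have more. Where it says the series, first, only, none or still open, it means among the compounds named here.

Three measured compounds form the background here. Compound 1 `CCCS(=O)(=O)c1cccc(C#Cc2c(Cl)cccc2OCC(=O)O)c1` and compound 3 `CCS(=O)(=O)c1ccc(C)c(C#Cc2cc(Cl)ccc2OCC(=O)O)c1` carry sulfone-bearing aryl groups on the alkyne, while compound 2 `O=C(O)COc1ccc(Cl)cc1C#Cc1ccc(Cl)s1` carries a 5-chlorothiophen-2-yl there. In an assay on CHO cells for displacement of a labelled ligand from prostaglandin D2 receptor 2 (Homo sapiens), read by scintillation counting (on this read-out higher numbers stand for weaker inhibition and lower numbers for stronger inhibition), compound 1 gives 55 nM and compound 3 gives 8.6 nM. In this assay compound 2 gives 183 nM, the highest of the three numbers, beyond the scatter from both of the others.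

The step under consideration leads from compound 2 to compound 4 `O=C(O)COc1ccc(Cl)cc1C#Cc1ccncc1`, not yet measured in this assay. The change is pyridin-4-yl in place of 5-chlorothiophen-2-yl on a triple-bonded carbon. For the measured compounds named here, no directly comparable pair among the measured compounds shows what such a swap does. Going by the values given here, the only guidance is that compound 2, with its 5-chlorothiophen-2-yl, already stands weakest of the three, and the entering pyridin-4-yl is a smaller departure from it than the sulfone-bearing groups of compound 1 and compound 3. The step from compound 2 to compound 4 is expected to be modest, likely towards a higher number, with a 2.2-fold higher number from compound 2 to compound 4 (0.34 log units; beyond the scatter). For compound 4 the estimate in this assay is 400 nM, within a range from 120 nM to 1500 nM.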

Compound 4, inhibition constant: 601 nM
The estimate for compound 4 lay 1.5-fold (0.18 log units) below the measured number; measured number inside the range.
By their numbers in this assay, from the lowest: compound 3; then compound 1; then compound 2; then compound 4.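

In this assay, pyridin-4-yl in place of 5-chlorothiophen-2-yl on a triple-bonded carbon gives a 3.3-fold higher number from compound 2 to compound 4 (0.52 log units; beyond the scatter), the only single-place comparison among the compounds shown, and it shows that the number responds to the ring at this place. The two groups match in heavy atoms, hydrogen-bond donors and acceptors, yet the step lies beyond the scatter, so these counts alone do not set the number here. Nothing measured here accounts for the difference between the two rings.

The compounds shown leave open what a plain phenyl or a pyridin-3-yl would give on the same carbon, and so whether ring size or the ring nitrogen carries the step. Also open, going by these compounds, is whether a chlorine or an amine on the pyridin-4-yl would return the number towards that of compound 2 at 183 nM.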